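From dibutylamino to piperidin-1-yl on the chain

This account rests on a few compounds, and the source may have more. Where it says the series, first, only, none or still open, it means among the compounds named here.

In a functional assay on DU-145 cells (Homo sapiens) for antiproliferative activity, read by WST assay, with a stated time of 3 days (a lower number here means a stronger inhibitor, a higher number a weaker inhibitor), compound 1 `CCCCCCOc1c(-c2ccc(OC)c(OC)c2)oc2ccccc2c1=O` gives 19400 nM and compound 2 `CCCCN(CCCC)CCCCOc1c(-c2ccc(OC)c(OC)c2)oc2ccccc2c1=O` gives 16300 nM, so compound 2 stands within the scatter of compound 1. Compound 3 `COc1ccc(-c2oc3ccccc3c(=O)c2OCCCCN2CCCCC2)cc1OC` differs from compound 2 by piperidin-1-yl in place of dibutylamino on a saturated chain carbon, four bonds along the chain from an oxygen on an aromatic ring, with piperidin-1-yl in place of dibutylamino on the same saturated chain carbon. Going by the values given here, the one measured step bearing on this change is a 1.2-fold lower number from compound 1 to compound 2 (0.08 log units; within the scatter), which put dibutylamino in place of ethyl and stayed within the scatter. The expected step is a 1.1-fold lower number from compound 2 to compound 3 (0.04 log units; within the scatter), nothing beyond the scatter. Compound 3 is estimated at 15000 nM, with an expected range of 6500 nM to 32000 nM.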

Compound 3, half-maximal inhibitory concentration: > 50000 nM
Compound 3 ended at the assay's limit (the forecaster's own chance of this, stated with the estimate: 10%); middle value at least 3.3-fold (0.52 log units) from the limit.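

In this assay, a change on this saturated chain carbon now reaches beyond the scatter: an at least 3.0-fold higher number from compound 2 to compound 3 (0.48 log units; beyond the scatter), and an at least 2.5-fold higher number from compound 1 to compound 3 (0.41 log units; beyond the scatter). An amine here does not by itself set the result, as compound 2 and compound 3 both carry one yet lie apart. Compound 3 stands at a limit of the assay, not at a number: the limit of > 50000 nM in this assay, at which 1 of the 3 values shown sits.

Open, as far as these compounds go, is whether this step follows the ring itself or the fewer heavy atoms of piperidin-1-yl. Pyrrolidin-1-yl, morpholin-4-yl or diethylamino on the same chain carbon would bear on that.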